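A few compounds are considered here, and "the series" means these few. Any claim that something is new, unique, unknown or untested is made for them only; others in the source may bear on it.

The series shares one core, varied at a single aromatic carbon. Compound 1 `CCCCCc1cc(C)c(C(=O)N=C(N)N)cc1S(C)(=O)=O` carries pentyl there; in a functional assay for inhibition of sodium/hydrogen exchanger (Oryctolagus cuniculus) (on this read-out lower numbers stand for stronger inhibition and higher numbers for weaker inhibition), compound 1 gives 27 nM. Compound 2 `Cc1cc(-c2ccccc2)c(S(C)(=O)=O)cc1C(=O)N=C(N)N` carries phenyl and gives 19 nM; compound 3 `Cc1cc(Sc2cccc(Cl)c2)c(S(C)(=O)=O)cc1C(=O)N=C(N)N` carries (3-chlorophenyl)sulfanyl and gives 37 nM. Compound 3 has the highest of the three numbers, yet a 1.4-fold higher number from compound 1 to compound 3 (0.14 log units; within the scatter) and a 1.9-fold higher number from compound 2 to compound 3 (0.29 log units; within the scatter) show that every variation at this carbon has stayed within the scatter, as does a 1.4-fold lower number from compound 1 to compound 2 (0.15 log units; within the scatter). Compound 4 `Cc1cc(Oc2ccccc2Cl)c(S(C)(=O)=O)cc1C(=O)N=C(N)N` is the next variation: 2-chlorophenoxy in place of (3-chlorophenyl)sulfanyl on an aromatic carbon. The entering group sits ortho to a methylsulfonyl group, meta to a methyl group and para to a group of 6 heavy atoms, where the leaving group sat. Within the data shown here, the steps that bear on this change are those at the same carbon, and none exceeded the scatter; nothing among the three measured compounds separates a sulfur-linked from an oxygen-linked aryl, or one chlorine placement from another. The expectation is therefore a step of a 1.2-fold lower number from compound 3 to compound 4 (0.09 log units; within the scatter), not beyond the scatter. Compound 4 is estimated at 30 nM, with a range from 12 nM to 75 nM.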

Compound 4, half-maximal inhibitory concentration: 14 nM
For compound 4 the middle estimate is 2.1-fold (0.33 log units) above the measured one, within the range that was stated.
By their numbers in this assay, from the lowest: compounds 4, 2, 1 and 3 (each within the scatter of the next, the first and the last beyond it).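

At this aromatic carbon, a 2.6-fold lower number from compound 3 to compound 4 (0.42 log units; beyond the scatter) is the only step shown that lies beyond the scatter in this assay, so exchanging (3-chlorophenyl)sulfanyl for 2-chlorophenoxy registers, though modestly. Compound 4 remains within the scatter of the other two compounds, as a 1.4-fold lower number from compound 2 to compound 4 (0.13 log units; within the scatter) and a 1.9-fold lower number from compound 1 to compound 4 (0.29 log units; within the scatter) show, so 2-chlorophenoxy is not separated from phenyl or pentyl here. No measurement shown accounts for the step.

The step changes the sulfur link to oxygen and moves the chlorine in one move, so the share of each remains unresolved; 3-chlorophenoxy or (2-chlorophenyl)sulfanyl would separate the two. Also open, as far as these compounds go, is how an amine, a carboxylic acid or an ethyl chain at this carbon would read out.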